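Replacing Fluoro with Methyl in Compound 2

The source may hold more compounds than are shown below. What is called first, only, known or untested is meant among the compounds shown, and "the series" means these compounds.

In a functional assay on cells (Tumor Cell line, Homo sapiens) for cytotoxicity (on this read-out lower numbers stand for stronger inhibition and higher numbers for weaker inhibition), compound 1 `CN(C)Cc1cc(C(=O)/C=C/c2ccc(Cl)c(Cl)c2)cc(CN(C)C)c1O` gives 2350 nM, while compound 2 `CN(C)Cc1cc(C(=O)/C=C/c2ccc(F)cc2)cc(CN(C)C)c1O` gives 20000 nM, the higher of the two numbers and so the weaker result. Compound 3 `Cc1ccc(/C=C/C(=O)c2cc(CN(C)C)c(O)c(CN(C)C)c2)cc1` has not yet been measured. It differs from compound 2 in one place: methyl in place of fluoro on an aromatic carbon. In words, this is methyl in place of fluoro on an aromatic carbon, para to a large group. Within the data shown here, one measured step bears on this change: an 8.5-fold higher number from compound 1 to compound 2 (0.93 log units; beyond the scatter), with 4-fluorophenyl replacing 3,4-dichlorophenyl. That step shows that the number can move beyond the scatter when this ring changes, but it involves different groups and gives only a rough scale. Among the measured compounds shown here, no measured compound carries methyl. A smaller move toward lower numbers is expected, namely a 2.2-fold lower number from compound 2 to compound 3 (0.35 log units; beyond the scatter). The estimated value for compound 3 is 9000 nM, with an expected range from 3000 nM to 25000 nM.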

Compound 3, half-maximal inhibitory concentration: 17800 nM
Compound 3: middle estimate off by 2.0-fold (0.30 log units), on the low side; low and high end bracket the measured number.
By their numbers in this assay, from the lowest: compound 1; then compounds 3 and 2 (each within the scatter of the next).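

In this assay, methyl in place of fluoro on this aromatic carbon gives a 1.1-fold lower number from compound 2 to compound 3 (0.05 log units; within the scatter) and so does not separate the two groups, although they differ in kind of atom. The change from the 3,4-dichlorophenyl of compound 1 to 4-methylphenyl gives a 7.6-fold higher number from compound 1 to compound 3 (0.88 log units; beyond the scatter) and stands close to the earlier step to 4-fluorophenyl, which shows that the gap from compound 1 is not tied to fluoro alone. Nothing measured here accounts for either result.

Going by these compounds, whether a single chloro on this carbon would be enough to reach the number of compound 1, or both chloro groups of the 3,4-dichlorophenyl are needed, remains open. So does the effect of a group of another type in this place, such as methoxy, an amine or a carboxylic acid.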